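Hydantoin series: methoxy to carbamoyl on the aryl ring

This account rests on a few compounds, and the source may have more. Where it says the series, first, only, none or still open, it means among the compounds named here.

Working notes on the series built on the shared core of compound 1 `COc1cccc(N2C(=O)N/C(=C\c3ccc(O)cc3)C2=O)c1`. In a functional assay on NCI-H292 cells (Homo sapiens) for antiproliferative activity (on this read-out lower numbers stand for stronger inhibition and higher numbers for weaker inhibition), compound 1 gives only a limit, > 200000 nM. Compound 2 `O=C(O)c1ccc(N2C(=O)N/C(=C\c3ccc(O)cc3)C2=O)cc1` carries a carboxylic acid in place of the methoxy and likewise reaches only a limit in this assay, > 200000 nM. For the measured compounds named here, compound 1 therefore stands at the edge of what this assay reports, and the same holds for the one other measured compound: the limit of > 200000 nM in this assay, at which 2 of the 2 values shown sit. Going by the values given here, no step between measured compounds can be sized, since neither value is a number.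

Compound 3 `O=C(NCC1CCCCC1)c1cccc(N2C(=O)N/C(=C\c3ccc(O)cc3)C2=O)c1` is the next compound to be measured in this assay. It differs from compound 1 in one place: (cyclohexylmethyl)carbamoyl in place of methoxy on an aromatic carbon. Among the compounds with values here, with both measured compounds sitting at the limit, there is no measured step on which to rest a direction. For the step from compound 1 to compound 3 a shift of about an at least 1.3-fold lower number from compound 1 to compound 3 (0.12 log units; that floor lies within the scatter) toward stronger inhibition is expected, but it may well stay within the scatter. For compound 3 the estimate in this assay is 150000 nM, within 30000 nM to 400000 nM, with a fair chance that only a limit is reported again.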

Compound 3, half-maximal inhibitory concentration: 17900 nM
The estimate for compound 3 lay 8.4-fold (0.92 log units) above the measured number; the whole stated range lies above it.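

The change from methoxy to (cyclohexylmethyl)carbamoyl on this aromatic carbon, meta to a large group, gives an at least 11-fold lower number from compound 1 to compound 3 (1.04 log units; beyond the scatter) in this assay. For the compounds shown here, this is the first sign that the position can affect the read-out, as the earlier compounds offered no measured step, and it shows that the larger group, with its six-membered non-aromatic ring and hydrogen-bond donor, is compatible with a measurable antiproliferative effect. Compound 3 is also the only compound shown with a number rather than a limit, so it gives the series its first measured reference point, while the other values remain at the edge of the assay: the limit of > 200000 nM in this assay, at which 2 of the 3 values shown sit.

The compounds shown do not separate the contribution of the amide link from that of the cyclohexylmethyl part, so it remains open whether an unsubstituted carbamoyl, a short N-methyl carbamoyl or an amine at this position would give a similar number. On these data alone, it is equally open whether a longer chain between the amide nitrogen and the ring, or a phenyl ring in place of the cyclohexyl ring, would move the value further in either direction.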